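The source may hold more compounds than are shown below. What is called first, only, known or untested is meant among the compounds shown, and "the series" means these compounds.

Measured in an ADME assay on CCRF-HSB-2 cells (Homo sapiens) for cytotoxicity, with a stated time of 7 days; on this read-out higher numbers stand for lower toxicity in this test and lower numbers for higher toxicity in this test:
- Compound 1 `C=CCOc1nc(N)nc2c1ncn2/C=C1/CC1(CO)CO`: > 20000 nM, a limit
- Compound 2 `CN(C)c1nc(N)nc2c1ncn2/C=C1/CC1(CO)CO`: > 20000 nM, a limit
- Compound 3 `Nc1nc(SC2CCCC2)c2ncn(/C=C3/CC3(CO)CO)c2n1`: 91000 nM

Within the data shown here, compound 3 gives the only actual number in this small set, 91000 nM. The remaining evidence is the limit of > 20000 nM in this assay, at which 2 of the 3 values shown sit, so the position of compound 3 relative to the other two cannot be fixed.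

Compound 4 `CCCCOc1nc(N)nc2c1ncn2/C=C1/CC1(CO)CO` has yet to be measured in this assay. It carries butoxy in place of cyclopentylsulfanyl on an aromatic carbon.

Two measured steps exchange a group at this same place for cyclopentylsulfanyl. They are a step that the limit leaves unreadable from compound 1 to compound 3 and a step that the limit leaves unreadable from compound 2 to compound 3. The first bears more closely, since allyloxy is the group in the set that most resembles butoxy, but neither step gives a size. Among the measured compounds shown here, no measured step therefore points to a change in either direction, and no shift beyond the scatter is expected in this assay. The expected change is a 1.5-fold lower number from compound 3 to compound 4 (0.18 log units; within the scatter). The assay may well report only a limit for compound 4, as it did for compound 1 and compound 2. For compound 4 the estimated value is 60000 nM, with an expected range from 20000 nM to 150000 nM.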

Compound 4, half-maximal cytotoxic concentration: > 20000 nM
Compound 4: no number, only a limit (the forecaster's own chance of this, stated with the estimate: 60%); the middle value lies beyond the limit too.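

Among these compounds, compound 4 also gives only a limit in this assay, so no step linking it with compound 1, compound 2 or compound 3 can be read: the limit of > 20000 nM in this assay, at which 3 of the 4 values shown sit.

The compounds shown leave open how the values of compound 1, compound 2 and compound 4 compare with one another and with that of compound 3 in this assay.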